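The compounds below may be only part of what the source reports. "The series", "measured", "known", "first", "only" and "open" are said of these compounds alone.

Three measured compounds share one core and differ only at the far end of the chain. Compound 1 `CC1CCCC(OCCCCCCN2C[C@H](O)[C@@H](O)[C@H](O)[C@H]2CO)C1C` is the analogue with a non-aromatic ring there. In an ADME assay on MDBK cells (Bos taurus) for cytotoxicity, read by MTT assay (on this read-out lower numbers stand for higher toxicity in this test and higher numbers for lower toxicity in this test), compound 1 gives > 500000 nM, which is a limit of the assay and not a number. Compound 2 `OC[C@@H]1[C@@H](O)[C@H](O)[C@@H](O)CN1CCCCCCOc1c(F)c(F)c(F)c(F)c1F` gives in this assay > 500000 nM, also a limit. Compound 3 `OC[C@@H]1[C@@H](O)[C@H](O)[C@@H](O)CN1CCCCCCOc1ccccc1C(F)(F)F` gives in this assay > 500000 nM, again a limit. All three measured results therefore sit at the limit of > 500000 nM in this assay, at which 3 of the 3 values shown sit, so compound 1 stands level with the other two on the numbers shown, and no ordering among them can be drawn. Among the compounds with values here, no step between measured compounds is defined in this set.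

Compound 4 `OC[C@@H]1[C@@H](O)[C@H](O)[C@@H](O)CN1CCCCCCOc1cc(F)ccc1F` is not yet measured. Relative to compound 1 the change is a group of 8 heavy atoms (6 carbon, 2 fluorine; one six-membered aromatic ring of carbon only) in place of a group of 8 heavy atoms (8 carbon; one six-membered non-aromatic ring of carbon only), on an oxygen on a saturated carbon.

Given that compound 1 sits at > 500000 nM and that the two aromatic analogues compound 2 and compound 3 likewise sit only at the limit, no step beyond the scatter is expected in either direction; the step from compound 1 to compound 4 is expected to be a number no higher from compound 1 to compound 4 (the limit leaves the size open). Compound 4 is estimated at 500000 nM, with a range from 200000 nM to 1000000 nM, and most probably the assay will again report only a limit for it.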

Compound 4, half-maximal cytotoxic concentration: > 500000 nM
Compound 4: only a limit was reported (the forecaster's own chance of this, stated with the estimate: 85%); the middle value sits exactly at the limit.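

No step can be read between compound 1 and compound 4, as both results are limits of the assay and not numbers: the limit of > 500000 nM in this assay, at which 4 of the 4 values shown sit.

The compounds shown leave open where the actual half-maximal cytotoxic concentration of any of them lies, and whether the 2,5-difluorophenyl group of compound 4 changes the result in this assay at all.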